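From one chlorine to two on the amide-bound phenyl

The compounds below may be only part of what the source reports. "The series", "measured", "known", "first", "only" and "open" are said of these compounds alone.

Three measured compounds share one core and differ only in the aryl group sitting on an amide-type nitrogen. Compound 1 `Cc1c(O)c(=O)ccn1CC(=O)N/N=C1\C(=O)N(CC(=O)Nc2ccc(Br)cc2)c2ccccc21` carries a 4-bromophenyl there, and in a functional assay on A549 cells (Homo sapiens) for cytotoxicity, read by MTT assay, with a stated time of 48 h (on this read-out higher numbers stand for an effect only at larger amounts of compound and lower numbers for an effect already at smaller amounts), compound 1 gives 29300 nM. Compound 3 `Cc1cccc(NC(=O)CN2C(=O)/C(=N\NC(=O)Cn3ccc(=O)c(O)c3C)c3ccccc32)c1C` carries a 2,3-dimethylphenyl, and in this assay compound 3 gives 39200 nM. Compound 2 `Cc1c(O)c(=O)ccn1CC(=O)N/N=C1\C(=O)N(CC(=O)Nc2ccccc2Cl)c2ccccc21` carries a 2-chlorophenyl; in this assay compound 2 reaches only a limit of the assay, > 100000 nM, so no number is known for it, only that it sits at the limit of > 100000 nM in this assay, at which 1 of the 3 values shown sits. Among the three values shown compound 2 thus stands apart: an at least 3.4-fold higher number from compound 1 to compound 2 (0.53 log units; beyond the scatter) and an at least 2.5-fold lower number from compound 2 to compound 3 (0.40 log units; beyond the scatter), whereas a 1.3-fold higher number from compound 1 to compound 3 (0.13 log units; within the scatter).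

Compound 4 `Cc1c(O)c(=O)ccn1CC(=O)N/N=C1\C(=O)N(CC(=O)Nc2cc(Cl)cc(Cl)c2)c2ccccc21` is not yet measured. It differs from compound 2 in one place: 3,5-dichlorophenyl in place of 2-chlorophenyl on an amide-type nitrogen. The two measured steps that touch compound 2 both replace the 2-chlorophenyl, one by 4-bromophenyl and one by 2,3-dimethylphenyl, and both lead out of the limit to a measurable number. The step is therefore expected to run the same way, downward and out of the limit: an at least 2.5-fold lower number from compound 2 to compound 4 (0.39 log units; beyond the scatter). For compound 4 the estimate in this assay is 40000 nM, with a range from 15000 nM to 150000 nM, while a second limit cannot be ruled out.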

Compound 4, half-maximal effective concentration: 22100 nM
Compound 4: the middle estimate sits 1.8-fold (0.26 log units) above what was measured; low and high end bracket the measured number.
By their numbers in this assay, from the lowest: compounds 4, 1 and 3 (each within the scatter of the next). At a limit, above all of these: compound 2.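

The 3,5-dichlorophenyl group shows that chlorine on this phenyl ring does not by itself keep a compound out of measurable range in this assay: the change brings an at least 4.5-fold lower number from compound 2 to compound 4 (0.65 log units; beyond the scatter). The new value also falls in with the two earlier measured compounds, with a 1.8-fold lower number from compound 3 to compound 4 (0.25 log units; within the scatter) and a 1.3-fold lower number from compound 1 to compound 4 (0.12 log units; within the scatter), so the 3,5-dichlorophenyl, 2,3-dimethylphenyl and 4-bromophenyl groups cannot be told apart here. Compound 2 is now the only one of the series left at a limit of the assay, not at a measured number: the limit of > 100000 nM in this assay, at which 1 of the 4 values shown sits.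

The step from compound 2 to compound 4 changes both the number of chlorines and where they sit, so the compounds shown cannot separate these two changes, and a 3-chlorophenyl or 4-chlorophenyl group would help to do so. Every aryl group shown carries only chlorine, bromine or methyl, which leaves open how this position would respond to a 4-aminophenyl or 4-carboxyphenyl group, and whether any group here could give a clearly lower number than those of compounds 1, 3 and 4.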